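The source may report more compounds than this note shows. Statements on the series, on what has been measured and on what is new or still open speak of the compounds shown alone.

Measured compounds:
- Compound 1, `Oc1ccccc1-c1cc(-c2ccsc2)cc(-c2ccccc2O)n1`, in an assay on isolated protein for inhibition of DNA topoisomerase 1 (Homo sapiens), with a stated time of 30 min, tested at 100 uM (a higher number here means a stronger effect of the compound at the concentration tested, a lower number a weaker effect), gives 0%
- Compound 2, `Oc1cccc(-c2cc(-c3ccsc3)cc(-c3ccccc3O)n2)c1`, in this assay gives 10.2%

Going by the values given here, compound 2 stands highest of the two numbers so far; the step of a number 10.2 percentage points higher from compound 1 to compound 2 (beyond the scatter) lifted it above compound 1 by a margin that lies beyond the usual scatter, though the read-out remains modest.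

Compound 3, `Oc1ccc(-c2cc(-c3ccsc3)cc(-c3ccccc3O)n2)cc1`, has not yet been measured in this assay. The change from compound 2 to compound 3 is 4-hydroxyphenyl in place of 3-hydroxyphenyl on an aromatic carbon. Among the compounds with values here, only one measured step bears on this, the step of a number 10.2 percentage points higher from compound 1 to compound 2 (beyond the scatter), which shows that moving the hydroxyl group around its phenyl ring can shift the read-out by a modest amount. Whether a further move of the same group continues that shift, or reverses it, cannot be read from two compounds. The expectation is therefore a small step, a number 1.8 percentage points higher from compound 2 to compound 3 (within the scatter), that may well fall within the scatter. For compound 3 the estimate in this assay is 12%, expected to lie between 0% and 28%.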

Compound 3, a percentage reported as inhibition, at one concentration (the size of the read-out at that concentration, not a potency): 13.8%
Compound 3: the middle estimate sits 1.8 percentage points below what was measured, and the stated range covers the measured number.
By their numbers in this assay, from the lowest: compound 1; then compounds 2 and 3 (each within the scatter of the next).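

In this assay, the new compound shows that the 3-hydroxyphenyl and 4-hydroxyphenyl groups, on the ring carbon next to the ring nitrogen, cannot be told apart: the change gives a number 3.6 percentage points higher from compound 2 to compound 3 (within the scatter). The 2-hydroxyphenyl group at this position now stands apart from both of the other placements, since putting 4-hydroxyphenyl in its place gives a number 13.8 percentage points higher from compound 1 to compound 3 (beyond the scatter), a step that, like the earlier one to the 3-hydroxyphenyl group, is beyond the scatter but modest in size. Nothing available explains why the 2-hydroxyphenyl group differs from the other two placements.

The compounds shown leave open whether the hydroxyl group is needed on this ring at all, and whether an amine or a carboxylic acid in its place would raise the read-out beyond this modest level. They also leave open what the remaining 2-hydroxyphenyl group and the thiophen-3-yl group contribute, and each read-out tells only how strong the effect is at the one concentration tested.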